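Chain length and cytotoxicity across compounds 1 to 3

The compounds below may be only part of what the source reports. "The series", "measured", "known", "first", "only" and "open" are said of these compounds alone.

Compound 1 `CCCCCCc1cn(C(c2ccccc2)c2cc3cc(Br)ccc3nc2OC)nn1` and compound 2 `CCCCc1cn(C(c2ccccc2)c2cc3cc(Br)ccc3nc2OC)nn1` differ only in the length of the saturated chain on the shared core. In an ADME assay on HeLa cells (Homo sapiens) for cytotoxicity, read by sulforhodamine B assay, with a stated time of 48 h, tested at 10 uM (on this read-out lower numbers stand for less inhibition and higher numbers for more inhibition at the one concentration tested (going by the name of the read-out)), compound 1 gives -0.97% and compound 2 gives -2.87%. Among the compounds with values here, the only measured step, a number 1.9 percentage points lower from compound 1 to compound 2 (within the scatter), is within the scatter, so the two values cannot be told apart. Within the data shown here, compound 2 holds the lowest of the two numbers so far in this assay, its nearest neighbour being compound 1 at a distance within the scatter.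

Compound 3 `CCCCCc1cn(C(c2ccccc2)c2cc3cc(Br)ccc3nc2OC)nn1` is not yet measured. Relative to compound 2 the change is methyl in place of hydrogen on a saturated chain carbon, four bonds along the chain from an aromatic carbon. Among the measured compounds shown here, the one step that bears on it is a number 1.9 percentage points lower from compound 1 to compound 2 (within the scatter), which removes an ethyl from the same chain position and moves the read-out by an amount within the scatter. As the change from compound 2 to compound 3 is a smaller version of that step, no shift beyond the scatter in this assay is expected in either direction. The expected step is a number 0.9 percentage points higher from compound 2 to compound 3 (within the scatter). Compound 3 is therefore estimated at -2% in this assay, with a range from -12% to 8%.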

Compound 3, a percentage reported as inhibition, at one concentration (the size of the read-out at that concentration, not a potency): -9.81%
Compound 3: the middle estimate sits 7.8 percentage points above what was measured; the measured number falls inside the stated range.
By their numbers in this assay, from the lowest: compounds 3, 2 and 1 (each within the scatter of the next).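

Single-carbon changes at this position can now be read from both sides. In this assay, within the data shown here, methyl in place of hydrogen on the saturated chain carbon, four bonds along the chain from an aromatic carbon, gives a number 6.9 percentage points lower from compound 2 to compound 3 (within the scatter), while hydrogen in place of methyl on the carbon five bonds along the chain gives a number 8.8 percentage points lower from compound 1 to compound 3 (within the scatter), so neither change can be told from repeat scatter and, with the earlier two-carbon step, no pair among the three chain lengths separates in this read-out. Nothing available explains the values or bears on why compound 3 gives the number it does.

The compounds shown leave open whether a much shorter chain, such as methyl or ethyl, or a much longer chain, such as decyl, would move the read-out beyond the scatter. They also leave open whether an amine or a carboxylic acid at the end of the chain would do so, since all three compounds carry plain saturated chains.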